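The compounds below may be only part of what the source reports. "The series", "measured", "known", "first", "only" and "open" are said of these compounds alone.

Compound 1 `Cc1cccc(/C(N)=N/NC(=S)N2CCCCC2)n1` gives 36.6% in a functional assay on A-431 cells (Homo sapiens) for cytotoxicity, read by MTT assay, with a stated time of 72 h, tested at 3 uM (on this read-out lower numbers stand for less inhibition of growth and higher numbers for more inhibition of growth at the one concentration tested), and compound 2 `Cc1cccc(/C(N)=N/NC(=S)N2CCCC2)n1` gives 47.2%. The two differ by pyrrolidin-1-yl in place of piperidin-1-yl on a thiocarbonyl carbon, and that change made the step of a number 10.6 percentage points higher from compound 1 to compound 2 (beyond the scatter). Compound 3 `Cc1ccnc(/C(N)=N/NC(=S)N2CCCCC2)c1` is built on a core that differs from the core of compound 1 in a way that is not broken down here; in this assay compound 3 gives 36.5%, a number within the scatter of that of compound 1. Compound 4 `Cc1ccnc(/C(N)=N/NC(=S)N2CCCC2)c1` carries the same change as compound 2, namely (pyrrolidin-1-yl in place of piperidin-1-yl on a thiocarbonyl carbon). Since the change moved compound 1 to compound 2 by a modest margin, a step of about the same size, a number 9.5 percentage points higher from compound 3 to compound 4 (within the scatter), is expected from compound 3 to compound 4 in this assay. Compound 4 is therefore estimated at 46%, between 35% and 57%.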

Compound 4, percent growth inhibition at one concentration: 63%
For compound 4 the middle estimate is 17 percentage points below the measured one; measured number above the stated range.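

Putting pyrrolidin-1-yl in place of piperidin-1-yl on a thiocarbonyl carbon gave, in this assay, a number 26.5 percentage points higher from compound 3 to compound 4 (beyond the scatter). The change raised the number on both cores, but its size did not carry over from one core to the other: the same change on two cores in this assay, a number 10.6 percentage points higher (beyond the scatter) from compound 1 to compound 2 and a number 26.5 percentage points higher (beyond the scatter) from compound 3 to compound 4, 15.9 percentage points apart, beyond the scatter of two such steps. The direction therefore held in these two pairs, while the size of the step differed with the core; two pairs do not show why, or whether either result would hold on a further core.

The compounds shown leave open how azetidin-1-yl, morpholin-4-yl or dimethylamino would behave on the same thiocarbonyl carbon. They also leave open what an ethyl group in place of the methyl group would do on either core.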